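Swapping an aryl group on a shared core: expected inhibition

The source may report more compounds than this note shows. Statements on the series, on what has been measured and on what is new or still open speak of the compounds shown alone.

Measured compounds:
- compound 1 `Nc1ccccc1NC(=O)/C=C/c1ccc(Cn2cnc3c(NC4CCCCC4)nc(Cl)nc32)cc1`: 18.7%
- compound 2 `Nc1ccccc1NC(=O)c1ccc(Cn2cnc3c(Nc4cccc(OC(F)(F)F)c4)nc(Cl)nc32)cc1`: 46.6%
- compound 3 `Nc1ccccc1NC(=O)c1ccc(CNc2nc(Cl)nc3c2ncn3Cc2ccccc2)cc1`: 11.5%

All three were tested in a functional assay on HCT-116 cells (Homo sapiens) for antiproliferative activity, read by CCK-8 assay, with a stated time of 72 h, tested at 8 uM; on this read-out higher numbers stand for a stronger effect at the one concentration tested and lower numbers for a weaker effect. Compound 2 stands highest of the three numbers. Its nearest neighbour is compound 1, whose value is lower by a gap beyond the usual scatter, and compound 3 lies further down still, also beyond the scatter. For the measured compounds named here, the three compounds differ in more than one place, so no single step between them can be read off.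

Compound 4 `Cc1ccc(Nc2nc(Cl)nc3c2ncn3Cc2ccc(C(=O)Nc3ccccc3N)cc2)cc1` has not yet been measured. It is derived from compound 2 by one change: 4-methylphenyl in place of 3-(trifluoromethoxy)phenyl on a nitrogen on an aromatic ring. The rest of the molecule, including the shared core and the amide-bearing part, is kept. Only the group on that one nitrogen is exchanged, so the aryl-amino arrangement that compound 2 carries is kept, while compounds 1 and 3 each lack it.

Going by the values given here, with no measured step of this kind available, the expectation for this assay rests on compound 2 alone. A modest change is expected, more likely downward than upward, giving an expected step of a number 8.6 percentage points lower from compound 2 to compound 4 (within the scatter). Compound 4 is therefore estimated at 38%, in a range from 15% to 60%.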

Compound 4, a percentage reported as inhibition, at one concentration (the size of the read-out at that concentration, not a potency): 81.5%
The estimate for compound 4 lay 43.5 percentage points below the measured number; the whole stated range lies below it.
By their numbers in this assay, from the lowest: compounds 3 and 1 (each within the scatter of the next); then compound 2; then compound 4.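

In this assay, putting 4-methylphenyl in place of 3-(trifluoromethoxy)phenyl on a nitrogen on an aromatic ring gives a number 34.9 percentage points higher from compound 2 to compound 4 (beyond the scatter), with the rest of the molecule unchanged. For the compounds shown here, this is the first clean evidence that the aryl group on this nitrogen strongly affects the read-out, since the earlier compounds differed in more than one place, and it shows that the group entering, with 7 heavy atoms and no oxygen or fluorine, can outperform the larger group of 11 heavy atoms that leaves. No evidence is available to explain the size of this step.

The swap changes the substituent and its place on the ring together, so the gain cannot yet be assigned to gaining the methyl group, losing the trifluoromethoxy group or moving the substituent. A plain phenyl group on the same nitrogen would help separate these possibilities, and an amine or a carboxylic acid on that ring would test how far this position tolerates other kinds of group.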